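Ethynyl for thiophen-3-yl on the methylthio core

The compounds below may be only part of what the source reports. "The series", "measured", "known", "first", "only" and "open" are said of these compounds alone.

Working notes on a small nucleoside-like series, all read in an ADME assay on MRC5 cells (Homo sapiens), read by MTT assay, with a stated time of 72 h; on this read-out lower numbers stand for stronger inhibition and higher numbers for weaker inhibition. Compound 1 `C#Cc1cn([C@@H]2O[C@H](CO)[C@@H](O)[C@H]2O)c2ncnc(OC)c12` gives only a limit of the assay, > 100000 nM. Compound 2 `C#Cc1cn([C@@H]2O[C@H](CO)[C@@H](O)[C@H]2O)c2ncnc(C)c12` gives 1440 nM in this assay. For the measured compounds named here, the one measured step, methyl in place of methoxy on an aromatic carbon, is an at least 69-fold lower number from compound 1 to compound 2 (1.84 log units; beyond the scatter); it is the only step that exceeds the scatter. Going by the values given here, compound 3 `CSc1ncnc2c1c(-c1ccsc1)cn2[C@@H]1O[C@H](CO)[C@@H](O)[C@H]1O` stands at a limit of the assay in this assay, > 100000 nM; no other compound shares its methylthio group, so no step reaches it, and with the limit of > 100000 nM in this assay, at which 2 of the 3 values shown sit, its position is known only as the limit.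

Compound 4 `C#Cc1cn([C@@H]2O[C@H](CO)[C@@H](O)[C@H]2O)c2ncnc(SC)c12` differs from compound 3 by ethynyl in place of thiophen-3-yl on an aromatic carbon. Among the compounds with values here, no measured step bears on this change: the step from compound 1 to compound 2 alters the group on the six-membered part of the core, not the group on the five-membered ring, and the ethynyl compounds 1 and 2 span the limit and a measurable number. For compound 4 the expected step is therefore uncertain, an at least 3.3-fold lower number from compound 3 to compound 4 (0.52 log units; beyond the scatter), with the limit itself remaining a likely outcome. The estimate for compound 4 is 30000 nM, within 3000 nM to 100000 nM.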

Compound 4, half-maximal inhibitory concentration: > 100000 nM
Compound 4 gave a limit, no number; the forecaster's own chance of this, stated with the estimate: 45%; at least 3.3-fold (0.52 log units) between middle value and limit.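

The step with methylsulfanyl in place of methyl on an aromatic carbon is an at least 69-fold higher number from compound 2 to compound 4 (1.84 log units; beyond the scatter), so the measurable number of compound 2 does not carry over to the methylsulfanyl compound. Ethynyl alone therefore does not give a measurable number in this assay: of the ethynyl compounds 1, 2 and 4, only compound 2, which carries methyl, gives one, while compounds 1 and 4 stay at a limit. The steps from compound 3 to compound 4 and from compound 1 to compound 4 cannot be read, so ethynyl in place of thiophen-3-yl has no readable size with methylsulfanyl kept, and methylsulfanyl cannot be ranked against methoxy: the limit of > 100000 nM in this assay, at which 3 of the 4 values shown sit.

Open, as far as these compounds go, is whether a group other than methyl at the carbon that bears methoxy, methyl or methylsulfanyl, such as an amine or an ethyl chain, also gives a measurable number. Also open, from the compounds shown here alone, is whether thiophen-3-yl combined with methyl would leave the limit, which would give the change from thiophen-3-yl to ethynyl a readable size.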